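Swapping the chlorinated ring for a methylated one

A few compounds are considered here, and "the series" means these few. Any claim that something is new, unique, unknown or untested is made for them only; others in the source may bear on it.

Compound 1 `COc1cc(N(Cc2nc3ccccc3[nH]2)S(=O)(=O)c2ccccc2)cc(OC)c1OC` gives 12400 nM in a functional assay on MGC-803 cells (Homo sapiens) for inhibition, read by MTT assay, with a stated time of 48 h; a lower number here means a stronger inhibitor, a higher number a weaker inhibitor. Compound 2 `COc1cc(N(Cc2nc3ccccc3[nH]2)C(=O)c2ccc(Br)cc2)cc(OC)c1OC` gives 14600 nM in this assay. Compound 3 `COc1cc(N(Cc2nc3ccccc3[nH]2)C(=O)c2cccc(Cl)c2)cc(OC)c1OC` gives > 50000 nM in this assay.

All three share one core and differ only in the group on the nitrogen attached to the aromatic ring. Compound 3 stands at the weak end of the series: its value is a limit of the assay rather than a number, the one at the limit of > 50000 nM in this assay, at which 1 of the 3 values shown sits. Compound 4 `COc1cc(N(Cc2nc3ccccc3[nH]2)C(=O)c2ccc(C)cc2)cc(OC)c1OC` differs from compound 3 by 4-methylphenyl in place of 3-chlorophenyl on a carbonyl carbon. For the measured compounds named here, two measured steps bear on this change. Going to the 3-chlorophenyl ring cost potency in both cases: an at least 4.0-fold higher number from compound 1 to compound 3 (0.60 log units; beyond the scatter) and an at least 3.4-fold higher number from compound 2 to compound 3 (0.53 log units; beyond the scatter), each beyond the scatter. By contrast, a 1.2-fold higher number from compound 1 to compound 2 (0.07 log units; within the scatter), so the 4-bromophenyl ring of compound 2 behaved much like the phenylsulfonyl of compound 1. A ring carrying its substituent in the manner of the 4-bromophenyl of compound 2 is therefore expected to recover a measurable number, giving an at least 2.5-fold lower number from compound 3 to compound 4 (0.39 log units; beyond the scatter). Compound 4 is estimated at 20000 nM, with a range of 8000 nM to 55000 nM.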

Compound 4, half-maximal inhibitory concentration: 30500 nM
Compound 4: the middle estimate sits 1.5-fold (0.18 log units) below what was measured, within the range that was stated.
By their numbers in this assay, from the lowest: compounds 1 and 2 (each within the scatter of the next); then compound 4. At a limit, above all of these: compound 3.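

Moving from the 3-chlorophenyl ring to the 4-methylphenyl ring in this assay gives an at least 1.6-fold lower number from compound 3 to compound 4 (0.21 log units; that floor lies within the scatter). Compound 3 has only a limit and not a number, so this floor is all that can be said about the change, and it does not establish a real gain: the limit of > 50000 nM in this assay, at which 1 of the 4 values shown sits. The new comparisons are more informative: methyl in place of bromo gives a 2.1-fold higher number from compound 2 to compound 4 (0.32 log units; beyond the scatter), and (4-methylphenyl)carbonyl in place of phenylsulfonyl gives a 2.5-fold higher number from compound 1 to compound 4 (0.39 log units; beyond the scatter), so both steps are modest but beyond the scatter, and compound 4 does not match compound 1 or compound 2.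

The compounds shown leave open how an amine or a carboxylic acid in place of the methyl would behave. A 4-chlorophenyl ring would help separate the effect of the chlorine itself from that of its place on the ring.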